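Phenyl replacing ethoxy on a penicillin-derived enone

A few compounds are considered here, and "the series" means these few. Any claim that something is new, unique, unknown or untested is made for them only; others in the source may bear on it.

Of the compounds shown here, three built on the same bicyclic core have been tested so far. Compound 1 `CC1(C)[C@H](C(=O)OC(c2ccccc2)c2ccccc2)N2C(=O)/C(=C/C(=O)c3ccccc3)[C@H]2S1(=O)=O`, compound 2 `CCOC(=O)/C=C1/C(=O)N2[C@@H]1SC(C)(C)[C@@H]2C(=O)OC(c1ccccc1)c1ccccc1` and compound 3 `CC1(C)S[C@@H]2/C(=C\C(=O)OC(c3ccccc3)c3ccccc3)C(=O)N2[C@H]1C(=O)OC(c1ccccc1)c1ccccc1` were each examined in a functional assay on HT-1080 cells (Homo sapiens) for cytotoxicity, read by MTT assay, with a stated time of 48 h; on this read-out lower numbers stand for stronger inhibition and higher numbers for weaker inhibition. In this assay compound 1 gives 19500 nM, compound 2 gives 25100 nM and compound 3 gives 15200 nM. The number for compound 2 is the highest of the three, but the gaps to compound 1 and to compound 3 both fall within the usual scatter of repeated measurements, so the three cannot be ranked against one another.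

Compound 4 `CC1(C)S[C@@H]2/C(=C\C(=O)c3ccccc3)C(=O)N2[C@H]1C(=O)OC(c1ccccc1)c1ccccc1` has not yet been measured. It differs from compound 2 in one place: phenyl in place of ethoxy on a carbonyl carbon. For the measured compounds named here, no change between measured compounds is available to guide a prediction, and the three known numbers sit close together, so no step beyond the scatter is expected in either direction. The estimate for compound 4 in this assay is 18000 nM, with a range from 9000 nM to 36000 nM, corresponding to an expected step of a 1.4-fold lower number from compound 2 to compound 4 (0.14 log units; within the scatter).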

Compound 4, half-maximal inhibitory concentration: 21100 nM
Compound 4: the middle estimate sits 1.2-fold (0.07 log units) below what was measured; low and high end bracket the measured number.
By their numbers in this assay, from the lowest: compounds 3, 1, 4 and 2 (each within the scatter of the next).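

Exchanging ethoxy for phenyl on a carbonyl carbon, which turns ethoxycarbonyl into benzoyl, gives a 1.2-fold lower number from compound 2 to compound 4 (0.08 log units; within the scatter) in this assay. For the compounds shown here, this is the first comparison here between two compounds that differ in only one place. It shows that, in this assay, a six-membered aromatic ring of carbon can take the place of the smaller, ring-free ethoxy with no difference that stands out from repeat-to-repeat variation, and no supporting data are available to explain this outcome.

What the compounds shown leave open is whether any group on this carbonyl carbon can move the number beyond the scatter. An amine or a carboxylic acid carried there, or a longer chain in place of ethoxy, would test this.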